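The source may hold more compounds than are shown below. What is called first, only, known or untested is meant among the compounds shown, and "the series" means these compounds.

Compound 1, `Cc1cc(N2CC[C@@H](C)[C@@H](N(C)c3ncnc4[nH]ccc34)C2)n2nc(SCC3CC3)nc2n1`: 36500 nM in a functional assay on BGC-823 cells (Homo sapiens) for inhibition, read by MTT assay, with a stated time of 72 h; a higher number here means a weaker inhibitor, a lower number a stronger inhibitor
Compound 2, `Cc1cc(N2CC[C@@H](C)[C@@H](N(C)c3ncnc4[nH]ccc34)C2)n2nc(SCc3ccc(F)c(Cl)c3)nc2n1`: 98900 nM in this assay
Compound 3, `COc1ccc(CSc2nc3nc(C)cc(N4CC[C@@H](C)[C@@H](N(C)c5ncnc6[nH]ccc56)C4)n3n2)cc1`: 69900 nM in this assay

All three share the same core and differ only in the group carried by the saturated chain carbon bound to the sulfur. Compound 3 sits close to both of its neighbours: the step of a 1.4-fold lower number from compound 2 to compound 3 (0.15 log units; within the scatter) and the step of a 1.9-fold higher number from compound 1 to compound 3 (0.28 log units; within the scatter) are both within the scatter, so no real ordering among these three can be claimed; only a 2.7-fold higher number from compound 1 to compound 2 (0.43 log units; beyond the scatter) reaches beyond it, and modestly so.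

Compound 4 is `Cc1cc(N2CC[C@@H](C)[C@@H](N(C)c3ncnc4[nH]ccc34)C2)n2nc(SCc3ccc(F)cc3)nc2n1`. Relative to compound 3 the change is fluoro in place of methoxy on an aromatic carbon. Within the data shown here, no measured step swaps these two groups directly. The closest guide is a 1.4-fold lower number from compound 2 to compound 3 (0.15 log units; within the scatter), where one substituted benzyl group replaced another without a change beyond the scatter. Compound 4 is therefore expected to stay near compound 3, with an expected step of a 1.0-fold higher number from compound 3 to compound 4 (0.00 log units; within the scatter). For compound 4 in this assay the estimate is 70000 nM, within a range from 30000 nM to 160000 nM.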

Compound 4, half-maximal inhibitory concentration: 44300 nM
The estimate for compound 4 lay 1.6-fold (0.20 log units) above the measured number; low and high end bracket the measured number.
By their numbers in this assay, from the lowest: compounds 1, 4, 3 and 2 (each within the scatter of the next, the first and the last beyond it).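

Putting fluoro in place of methoxy on this aromatic ring gives a 1.6-fold lower number from compound 3 to compound 4 (0.20 log units; within the scatter) in this assay, so these two groups cannot be told apart at this position. Hydrogen in place of chloro gives a 2.2-fold lower number from compound 2 to compound 4 (0.35 log units; beyond the scatter), a modest step and the only new one beyond the scatter, so this single atom shifts the number more than the fluoro-for-methoxy swap does. The 4-fluorophenyl group also stays level with cyclopropyl, with a 1.2-fold higher number from compound 1 to compound 4 (0.08 log units; within the scatter) against a 2.7-fold higher number from compound 1 to compound 2 (0.43 log units; beyond the scatter) for the 3-chloro-4-fluorophenyl group, so the earlier gap does not extend to every benzyl group.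

No measurement shown here explains why the chloro atom matters. Also open, going by these compounds, is whether an amine or a carboxylic acid on this ring, or a longer chain on the sulfur, would shift the number.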